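Trimming the Long Chain of Compound 2

A few compounds are considered here, and "the series" means these few. Any claim that something is new, unique, unknown or untested is made for them only; others in the source may bear on it.

In a physicochemical assay for lipophilicity, in phosphate buffer, measured as octanol-water partition, at pH 11.5 (a higher number here means a more lipophilic compound, a lower number a more polar compound), compound 2 (`CCCCCCCCCCCCNC(=N)NC(=N)Nc1ccc(Cl)cc1`) gives 7.13, the highest of the three numbers available. Compound 3 (`CCCCCCS(=O)(=O)c1ccc(NC(=N)NC(=N)NCCCCCCNC(=N)NC(=N)Nc2ccc(S(=O)(=O)CCCCCC)cc2)cc1`) follows at 5.1 and compound 1 (`CCCCOC(=N)NC(=N)Nc1ccc(Cl)cc1`) gives 3.32, both lower than compound 2 by more than the scatter. The next compound to be measured, compound 4 (`CCCCCCCCCCNC(=N)NC(=N)Nc1ccc(Cl)cc1`), differs from compound 2 in one place: hydrogen in place of ethyl on a saturated chain carbon, ten or more bonds along the chain from an amine nitrogen. For the measured compounds named here, no measured pair isolates such a change, so the size of the step remains a judgement. The expected change is a number 1.03 log units lower from compound 2 to compound 4 (beyond the scatter), a fall beyond the scatter. The estimated value for compound 4 is 6.1, with an expected range from 5.6 to 6.6.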

Compound 4, partition coefficient: 6.13
For compound 4 the middle estimate is 0.03 log units below the measured one, within the range that was stated.
By their numbers in this assay, from the lowest: compound 1; then compound 3; then compound 4; then compound 2.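

In this assay, for the compounds shown here, hydrogen in place of ethyl on this saturated chain carbon gives a number 1.00 log units lower from compound 2 to compound 4 (beyond the scatter), the first measured step between two compounds that differ in one place. It shows that a change this far along the chain from the amine nitrogen moves the number by more than the scatter. No measurement shown here accounts for the size of this step.

Going by these compounds, whether a longer chain than that of compound 2 would give a step of similar size remains open. So does the effect of a hydroxyl or a carboxylic acid at the end of the chain.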